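Methylating the indole nitrogen: a second test of one change

A few compounds are considered here, and "the series" means these few. Any claim that something is new, unique, unknown or untested is made for them only; others in the source may bear on it.

Measured so far:
Compound 1, `c1ccc(NCc2cc3ccccc3[nH]2)cc1`, gives 320 nM.
Compound 2, `Cn1c(CNc2ccccc2)cc2ccccc21`, gives 75000 nM.
Compound 3, `CN(Cc1ccccc1)Cc1cc2ccccc2[nH]1`, gives 700 nM.

All three numbers come from an assay for inhibition of Amine oxidase [flavin-containing] B (Bos taurus), read by fluorescence; a lower number here means a stronger inhibitor, a higher number a weaker inhibitor. Compound 1 and compound 2 differ in one place only: methyl in place of hydrogen on an aromatic nitrogen. That single change produced a 230-fold higher number from compound 1 to compound 2 (2.37 log units; beyond the scatter), so compound 2 is a far weaker inhibitor than compound 1.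

Compound 3 shares its core with compound 1, but the difference between the two cores is not broken down here. Compound 3 stands between the other two: its value is higher than that of compound 1 and far lower than that of compound 2, both gaps lying beyond the scatter.

Compound 4, `CN(Cc1ccccc1)Cc1cc2ccccc2n1C`, has not yet been measured. It differs from compound 3 by methyl in place of hydrogen on an aromatic nitrogen. Within the data shown here, this is the same kind of change as the one from compound 1 to compound 2, though the surroundings are described differently: in compound 1 the nitrogen sits next to the ring atom that bears a group of 8 heavy atoms, while in compound 3 it sits next to the ring atom that bears a large group. Because the earlier change gave a 230-fold higher number from compound 1 to compound 2 (2.37 log units; beyond the scatter), a step of similar size is expected here, so in this assay compound 4 is expected to show a 110-fold higher number from compound 3 to compound 4 (2.06 log units; beyond the scatter). The estimated value for compound 4 is 80000 nM, with a plausible range from 10000 nM to 500000 nM, resting on a single precedent and therefore uncertain.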

Compound 4, inhibition constant: 9700 nM
Compound 4: middle estimate off by 8.2-fold (0.92 log units), on the high side; measured number below the stated range.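

In this assay, putting a methyl in place of the hydrogen on the aromatic nitrogen again gave a weaker inhibitor, with a 14-fold higher number from compound 3 to compound 4 (1.14 log units; beyond the scatter), so the direction of the change carried over from one core to the other and the step remained large. Its size did not carry over, however, and the difference is too great to dismiss as ordinary variation in the measurements: the same change on two cores in this assay, a 230-fold higher number (2.37 log units; beyond the scatter) from compound 1 to compound 2 and a 14-fold higher number (1.14 log units; beyond the scatter) from compound 3 to compound 4, 17-fold (1.23 log units) apart, beyond the scatter of two such steps. A change of this kind can therefore be trusted here to point the same way on these two cores, but the step seen on one core is a poor guide to the exact size of the step on the other, and two pairs do not show why the sizes differ or whether the direction would hold on a third core.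

The only groups shown on this nitrogen are hydrogen and methyl, so it remains open whether an ethyl group, a longer chain or an acetyl group there would weaken inhibition further, less or not at all. On these data alone, it is also open whether a step on any further core would resemble the larger step, the smaller one or neither.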